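Two hexylphenyl ketones and an inactive cinnamoyl amide

The source may report more compounds than this note shows. Statements on the series, on what has been measured and on what is new or still open speak of the compounds shown alone.

Measured so far:
- compound 1 `CCCCCCc1ccc(C(=O)CCN(C(C)C)C(C)C)cc1` gives 2000 nM in an in vitro assay on BL21-DE3 cells for displacement of a labelled ligand from thyroid hormone receptor beta (Homo sapiens), read by fluorescence polarization; a higher number here means a weaker inhibitor, a lower number a stronger inhibitor
- compound 2 `C/C=C/C(=O)Nc1ccc(CCCCCC)cc1` gives > 100000 nM in this assay, which is a limit of the assay and not a number

Compound 2 thus stands at the limit of > 100000 nM in this assay, at which 1 of the 2 values shown sits, and no measurable value separates it from compound 1 in this assay. Compound 3 `CCCCCCc1ccc(C(=O)C2CO2)cc1` is not yet measured. It differs from compound 2 by (oxiran-2-yl)carbonyl in place of ((prop-1-en-1-yl)carbonyl)amino on an aromatic carbon. Among the measured compounds shown here, no measured pair of this kind exists here, so the size of the step is uncertain; the only anchor is compound 1, whose ketone on the same core gives a measurable value. Compound 3 is estimated at 50000 nM in this assay, with a range from 10000 nM to 200000 nM. This estimate means an expected step of an at least 2.0-fold lower number from compound 2 to compound 3 (0.30 log units; that floor lies within the scatter), with a fair chance that compound 3 is again reported only as a limit.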

Compound 3, half-maximal inhibitory concentration: 19100 nM
Compound 3: the middle estimate sits 2.6-fold (0.42 log units) above what was measured; the measured number falls inside the stated range.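

On an aromatic carbon para to a hexyl group, placing (oxiran-2-yl)carbonyl where ((prop-1-en-1-yl)carbonyl)amino stood gives an at least 5.2-fold lower number from compound 2 to compound 3 (0.71 log units; beyond the scatter). The group that enters has no hydrogen-bond donor and compound 3 has no amine, yet in this assay compound 3 reads 19100 nM, so neither is required for a measurable value on this core. The full size of the step cannot be given, as the value of compound 2 is a limit of the assay and not a number: the limit of > 100000 nM in this assay, at which 1 of the 3 values shown sits.

The compounds shown leave open whether the three-membered ring matters or a ketone at this position is enough, which an acetyl group or a cyclopropyl ketone on the same core could test. They also leave open how a butyl chain in place of the hexyl group would read.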